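Swapping Iodine for Thiophene on Two Related Cores

The compounds below may be only part of what the source reports. "The series", "measured", "known", "first", "only" and "open" are said of these compounds alone.

Of the compounds shown here, three have been tested in an ADME assay on HEL cells (Homo sapiens) for cytotoxicity, with a stated time of 3 days (on this read-out higher numbers stand for lower toxicity in this test and lower numbers for higher toxicity in this test), and a fourth awaits measurement. Compound 1 `Cc1cc(I)c2ncc(CSCCc3ccccc3)n2c1` carries an iodo group on its core. In this assay compound 1 gives >= 4 ug/mL, which is a limit of the assay rather than a number. Compound 2 `Cc1cc(-c2cccs2)c2ncc(CSCCc3ccccc3)n2c1` differs from compound 1 in one place: thiophen-2-yl in place of iodo on an aromatic carbon. In this assay compound 2 gives 100 ug/mL. The step between them, a step that the limit leaves unreadable from compound 1 to compound 2, cannot be sized because the limit of >= 4 ug/mL in this assay, at which 1 of the 3 values shown sits, stands where compound 1 would need a number.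

Compound 3 `Cc1cc(I)cn2c(CSCCc3ccccc3)cnc12` is built from the same atoms as compound 1, joined differently; the difference between the two cores is not broken down here. In this assay compound 3 gives >= 0.8 ug/mL, again a limit of the assay and not a number.

Compound 4 `Cc1cc(-c2cccs2)cn2c(CSCCc3ccccc3)cnc12` is the not yet measured partner of compound 3, and differs from it in one place: thiophen-2-yl in place of iodo on an aromatic carbon. This is the same kind of change as from compound 1 to compound 2, though not the same: in compound 1 the changed carbon is ortho to a fused ring, whereas in compound 3 it is para to a fused ring. Within the data shown here, the only number among the measured compounds comes from compound 2 with 100 ug/mL, and the expectation for compound 4 rests on it alone. Compound 4 is expected to give 50 ug/mL in this assay, within a range of 10 ug/mL to 100 ug/mL. The expected step, a step that the limit leaves unreadable from compound 3 to compound 4, cannot be set beside the earlier one, which the limit left unreadable.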

Compound 4, minimum cytotoxic concentration: 20 ug/mL
Compound 4: middle estimate off by 2.5-fold (0.40 log units), on the high side; low and high end bracket the measured number.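

The step from compound 3 to compound 4 cannot be sized, since compound 3 has only a limit of the assay and not a number: the limit of >= 0.8 ug/mL in this assay, at which 1 of the 4 values shown sits. The compounds shown leave open how far the iodo compounds, compound 1 and compound 3, lie from their thiophen-2-yl partners, compound 2 and compound 4, and whether that swap has the same size on both cores.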